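A few compounds are considered here, and "the series" means these few. Any claim that something is new, unique, unknown or untested is made for them only; others in the source may bear on it.

Compounds 1 to 3 share one core and differ only in the group on a saturated chain carbon bound to an aromatic nitrogen. In a physicochemical assay for solubility (a higher number here means a more soluble compound, a lower number a less soluble compound), compound 1 `CNC(=O)c1cc(C(=O)NC2CC2)cn(Cc2ccc(C)cc2)c1=O`, which carries 4-methylphenyl, gives 24 ug/mL. Compound 2 `CNC(=O)c1cc(C(=O)NC2CC2)cn(Cc2cccc3cn[nH]c23)c1=O` gives >= 181 ug/mL, which is a limit of the assay. Compound 3 `CNC(=O)c1cc(C(=O)NC2CC2)cn(Cc2ccc3nc[nH]c3c2)c1=O` gives >= 163 ug/mL, also a limit rather than a number. Compound 4 `CNC(=O)c1cc(C(=O)NC2CC2)cn(Cc2cccc3occc23)c1=O` brings a new group: 1-benzofuran-4-yl in place of 1H-benzimidazol-6-yl on a saturated chain carbon bound to an aromatic nitrogen. Within the data shown here, two measured steps bear on this change: an at least 7.5-fold higher number from compound 1 to compound 2 (0.87 log units; beyond the scatter) and an at least 6.7-fold higher number from compound 1 to compound 3 (0.83 log units; beyond the scatter), both beyond the scatter. Compound 4 gives up the nitrogen-containing 1H-benzimidazol-6-yl, so a return towards compound 1 and its 24 ug/mL is expected. The expected step in this assay is an at least 4.6-fold lower number from compound 3 to compound 4 (0.66 log units; beyond the scatter), a fall beyond the scatter. The estimate for compound 4 is 35 ug/mL, within an expected range of 12 ug/mL to 100 ug/mL.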

Compound 4, solubility: >= 110 ug/mL
Compound 4: no number, only a limit (the forecaster's own chance of this, stated with the estimate: 10%); middle value at least 3.1-fold (0.49 log units) away from the limit.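

With 1-benzofuran-4-yl on the saturated chain carbon bound to an aromatic nitrogen, this assay shows an at least 4.5-fold higher number from compound 1 to compound 4 (0.66 log units; beyond the scatter). This group contains no nitrogen and no hydrogen-bond donor, so a rise at this position does not require the ring nitrogens present in compound 2 and compound 3. Compound 4 gives >= 110 ug/mL, which is a limit of the assay, and because compound 2 and compound 3 also have limits, the steps among these three cannot be read.

As far as these compounds go, how these three groups rank remains open. Also open, from the compounds shown here alone, is whether an all-carbon naphthyl group, or a phenyl group bearing an amine, would give a similar rise.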